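Swapping fluorine positions on the benzyl group of compound 2

The source may report more compounds than this note shows. Statements on the series, on what has been measured and on what is new or still open speak of the compounds shown alone.

Measured so far in an assay on FRT cells for positive allosteric modulation of Cystic fibrosis transmembrane conductance regulator variant N1303K (Homo sapiens), in the presence of a further agent that is not named here; on this read-out higher numbers stand for an effect only at larger amounts of compound and lower numbers for an effect already at smaller amounts:
compound 1 `COc1ccc2[nH]c3c(c2c1)CCNC31CCN(Cc2cc(F)cc(Cl)c2)CC1`: 2500 nM
compound 2 `COc1ccc2[nH]c3c(c2c1)CCNC31CCN(Cc2ccc(F)cc2F)CC1`: 2000 nM

For the measured compounds named here, compound 2 shows the lower of the two numbers, but the only measured step, a 1.3-fold lower number from compound 1 to compound 2 (0.10 log units; within the scatter), is within the scatter, so the two compounds cannot be told apart. Compound 3 `COc1ccc2[nH]c3c(c2c1)CCNC31CCN(Cc2cc(F)cc(F)c2)CC1` keeps the shared core and differs from compound 2 only in the change (3,5-difluorophenyl in place of 2,4-difluorophenyl on a saturated chain carbon bound to an amine nitrogen in a ring). Going by the values given here, the one measured step concerns the same attachment point, swapping one halogenated phenyl ring for another, and it produced no change beyond the scatter. On that basis the expected step of a 1.3-fold higher number from compound 2 to compound 3 (0.10 log units; within the scatter) is none beyond the scatter in either direction, and compound 3 is estimated to give 2500 nM in this assay, with a range from 1000 nM to 6000 nM.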

Compound 3, half-maximal effective concentration: 11100 nM
Estimate against measurement, compound 3: 4.4-fold (0.65 log units) below; the measured number lies above the stated range.
By their numbers in this assay, from the lowest: compounds 2 and 1 (each within the scatter of the next); then compound 3.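

In this assay, this position turns out to respond to where the halogens sit on the ring, not only to which ring is present: the same atoms, rearranged as 3,5-difluorophenyl in place of 2,4-difluorophenyl, give a 5.6-fold higher number from compound 2 to compound 3 (0.74 log units; beyond the scatter). The earlier swap of one halogenated ring for another stayed within the scatter, so that flat picture does not hold for every ring at this place. Fluoro in place of chloro on an aromatic carbon also matters here, with a 4.4-fold higher number from compound 1 to compound 3 (0.65 log units; beyond the scatter), so 3-chloro-5-fluorophenyl and 3,5-difluorophenyl are not interchangeable either. Nothing shown here gives a reason for these steps.

It remains open which single fluorine accounts for the step from the 2,4-difluorophenyl ring. As far as these compounds go, it is also open whether a ring carrying one fluorine, a methoxy group or a nitrile would stay with compound 1 and compound 2 or move towards compound 3.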